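Swapping a thiophene for a pyrazole on a shared core

The source may report more compounds than this note shows. Statements on the series, on what has been measured and on what is new or still open speak of the compounds shown alone.

Of the compounds shown here, three sharing one core have been tested in a functional assay for activation of Alpha-1B adrenergic receptor (Homo sapiens), read by calcium flux; a lower number here means that less compound is needed, a higher number that more compound is needed for the effect. Compound 1 `c1ccc(-c2ccncc2)c(OCC2=NCCN2)c1` carries a pyridin-4-yl group; in this assay compound 1 gives only a limit of the assay, < 100000 nM, not a number. Compound 2 `c1ccc(-c2ccoc2)c(OCC2=NCCN2)c1` carries furan-3-yl and in this assay compound 2 gives 5.01 nM. Compound 3 `c1ccc(-c2ccsc2)c(OCC2=NCCN2)c1` carries thiophen-3-yl and in this assay compound 3 gives 15.9 nM, the higher of the two readable numbers; the step of a 3.2-fold higher number from compound 2 to compound 3 (0.50 log units; beyond the scatter) is modest but real. The steps a step that the limit leaves unreadable from compound 1 to compound 2 and a step that the limit leaves unreadable from compound 1 to compound 3 cannot be sized (the limit of < 100000 nM in this assay, at which 1 of the 3 values shown sits).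

Compound 4 `c1ccc(-c2cc[nH]n2)c(OCC2=NCCN2)c1` is the next change: 1H-pyrazol-3-yl in place of thiophen-3-yl on an aromatic carbon. Going by the values given here, no measured step swaps one five-membered ring for another with an added hydrogen-bond donor, so the guidance is thin. The two readable five-membered rings lie close together, while the six-membered pyridine of compound 1 gave no number. The expectation for compound 4 is a weaker result, a step of about a 6.3-fold higher number from compound 3 to compound 4 (0.80 log units; beyond the scatter), giving an estimated 100 nM with a range from 10 nM to 2000 nM.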

Compound 4, half-maximal effective concentration: 79.4 nM
Compound 4: the middle estimate sits 1.3-fold (0.10 log units) above what was measured, within the range that was stated.
By their numbers in this assay, from the lowest: compound 2; then compound 3; then compound 4.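

The position distinguishes between five-membered aromatic rings of equal heavy-atom count: in this assay, 1H-pyrazol-3-yl gives a 5.0-fold higher number from compound 3 to compound 4 (0.70 log units; beyond the scatter), and against furan-3-yl it gives a 16-fold higher number from compound 2 to compound 4 (1.20 log units; beyond the scatter). Compound 4 differs from compound 3 by having two ring nitrogens in place of a ring sulfur and by carrying a hydrogen-bond donor, which thiophen-3-yl lacks, but this single swap cannot show which of these differences accounts for the step. The step from compound 1 to compound 4 cannot be read, like the other steps from compound 1: the limit of < 100000 nM in this assay, at which 1 of the 4 values shown sits.

On these data alone, it remains open whether the ring hydrogen on nitrogen matters in itself, a question that a 1-methylpyrazol-3-yl group would help to separate from the change in ring atoms. As far as these compounds go, how a plain phenyl ring or an open-chain amide would read at this position also remains unknown.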